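The source may report more compounds than this note shows. Statements on the series, on what has been measured and on what is new or still open speak of the compounds shown alone.

Three close relatives share one core. Compound 1 `O=c1[nH]c(=O)n(Cc2ccccc2)cc1Nc1ccccc1` carries in an ADME assay on Akata cells (Homo sapiens) for cytotoxicity, read by XTT assay (on this read-out lower numbers stand for higher toxicity in this test and higher numbers for lower toxicity in this test), the entry "not determined" (no result reported). For compound 2 `Cc1cccc(Cn2cc(Nc3ccccc3)c(=O)[nH]c2=O)c1` the test reports only a limit, > 100000 nM. Compound 3 `O=c1[nH]c(=O)n(Cc2cccc(Cl)c2)cc1Nc1ccccc1` likewise stands at a limit of the test, > 100000 nM. The step that the two limits leave unreadable from compound 2 to compound 3 cannot be read because the limit of > 100000 nM in this assay, at which 2 of the 3 values shown sit, is where both of these values sit. Compound 4 `O=c1[nH]c(=O)n(Cc2cccc(Oc3ccccc3)c2)cc1Nc1ccccc1` differs from compound 3 by phenoxy in place of chloro on an aromatic carbon. Since no readable step exists among the measured compounds, no direction can be taken from them. For compound 4 the step of a number no higher from compound 3 to compound 4 (the limit leaves the size open) is expected to stay within the scatter of the test. The estimated value of compound 4 is 100000 nM, with a range from 30000 nM to 300000 nM.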

Compound 4, half-maximal cytotoxic concentration: > 100000 nM
Compound 4 was reported as a limit; the forecaster's own chance of this, stated with the estimate: 60%; the middle value sits exactly at the limit.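

In this assay, for the compounds shown here, no step among compound 2, compound 3 and compound 4 can be read, because all three stand at one limit: the limit of > 100000 nM in this assay, at which 3 of the 4 values shown sit. The compounds shown leave open whether methyl, chloro or phenoxy changes the half-maximal cytotoxic concentration at all.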